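The source may report more compounds than this note shows. Statements on the series, on what has been measured and on what is new or still open speak of the compounds shown alone.

Measured in an ADME assay on HeLa cells (Homo sapiens) for cytotoxicity, read by MTT assay; a lower number here means a stronger inhibitor, a higher number a weaker inhibitor:

- Compound 1 `COc1ccc(C[C@H]2COC(=O)[C@@H]2Cc2ccc(OCc3cn(-c4ccc(F)cc4)nn3)c(OC)c2)cc1OC` gives >= 600000 nM (a limit)
- Compound 2 `COc1ccc(C[C@H]2COC(=O)[C@@H]2Cc2ccc(OCC(=O)Nc3ccc(C)cc3)c(OC)c2)cc1OC` gives 228000 nM
- Compound 3 `COc1ccc(C[C@H]2COC(=O)[C@@H]2Cc2ccc(OCC(=O)N3CCCC3)c(OC)c2)cc1OC` gives >= 600000 nM (a limit)

Compound 1 has no exact number, only a limit, which is the limit of >= 600000 nM in this assay, at which 2 of the 3 values shown sit, here.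

Compound 4 `COc1ccc(C[C@H]2COC(=O)[C@@H]2Cc2ccc(OCc3cn(Cc4ccccc4Cl)nn3)c(OC)c2)cc1OC` differs from compound 1 in one place, with 2-chlorobenzyl in place of 4-fluorophenyl on an aromatic nitrogen, counted as 2-chlorobenzyl in place of 4-fluorophenyl on an aromatic nitrogen here.

Going by the values given here, no measured step changes this group on its own. The nearest evidence comes from replacing the whole group on the saturated chain carbon. That replacement gives an at least 2.6-fold lower number from compound 1 to compound 2 (0.42 log units; beyond the scatter) and, from the other side of compound 2, an at least 2.6-fold higher number from compound 2 to compound 3 (0.42 log units; beyond the scatter) as well. Both steps are at least modest and beyond the scatter, while a step that the two limits leave unreadable from compound 1 to compound 3 cannot be sized. Among the compounds with values here, compound 2 is thus the only compound with an exact number, and the change in compound 4 is narrower than the one that led to it.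

In this assay only a small step is therefore expected, towards a lower number if there is one at all, and another limit is quite possible. The expected change is an at least 1.3-fold lower number from compound 1 to compound 4 (0.12 log units; that floor lies within the scatter) as an estimate. For compound 4 the estimated value is 450000 nM with an expected range from 170000 nM to 1000000 nM in this assay.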

Compound 4, half-maximal inhibitory concentration: 84500 nM
For compound 4 the middle estimate is 5.3-fold (0.73 log units) above the measured one; the whole stated range lies above it.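

In this assay, 2-chlorobenzyl in place of 4-fluorophenyl on an aromatic nitrogen gives an at least 7.1-fold lower number from compound 1 to compound 4 (0.85 log units; beyond the scatter), so the group at this position can move the read-out on its own while the rest of the molecule stays the same. The earlier steps shown here replaced the whole group on the saturated chain carbon, whereas compound 4 keeps the five-membered aromatic ring with 3 nitrogen and still has an exact number, so an exact number in this set does not depend on the (4-methylphenyl)carbamoyl group of compound 2. The size of the step is only a floor, since compound 1 stands at a limit: the limit of >= 600000 nM in this assay, at which 2 of the 4 values shown sit.

This one change swaps the halogen and also adds a carbon between the ring nitrogen and the benzene ring, so the compounds shown cannot say which part of it carries the step. Unsubstituted benzyl and 4-fluorobenzyl on the same nitrogen would separate those two parts, and a benzyl group carrying an amine would show whether this position also accepts a basic nitrogen.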